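A Methoxy Group on a Thiosemicarbazone at the Limit

The compounds below may be only part of what the source reports. "The series", "measured", "known", "first", "only" and "open" are said of these compounds alone.

Compound 1 `CC1=CC[C@H](C(C)(C)NC(=S)N/N=C/c2ccccc2O)CC1`: 16600 nM in a functional assay on HT-29 cells (Homo sapiens) for inhibition, read by sulforhodamine B assay, with a stated time of 48 h; a higher number here means a weaker inhibitor of growth, a lower number a stronger inhibitor of growth
Compound 2 `CC1=CC[C@H](C(C)(C)NC(=S)N/N=C(\C)c2ccccc2)CC1`: > 100000 nM in this assay

Compound 1 gives a measured number, 16600 nM. Compound 2 does not: its value is a limit of this assay and not a number, and compound 2 therefore stands at the limit of > 100000 nM in this assay, at which 1 of the 2 values shown sits. For the measured compounds named here, the two compounds differ in more than one place, so no single step between them is known; their values show only that compound 1 was measurable and compound 2 was not.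

Compound 3 `COc1ccc(/C(C)=N/NC(=S)NC(C)(C)[C@H]2CC=C(C)CC2)cc1` differs from compound 2 by methoxy in place of hydrogen on an aromatic carbon. Going by the values given here, no measured pair in this set carries that change, and the starting point is itself only a limit. The step is therefore expected to be a number no higher from compound 2 to compound 3 (the limit leaves the size open), nothing beyond the scatter in either direction. Compound 3 is expected at 100000 nM, within 30000 nM to 300000 nM, most likely again reported only as a limit.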

Compound 3, concentration for total growth inhibition: > 100000 nM
Compound 3 was reported as a limit; the forecaster's own chance of this, stated with the estimate: 70%; the middle value lies on the limit itself.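

For the compounds shown here, compound 2 and compound 3 both stand only as limits in this assay and no step from the one to the other can be read: the limit of > 100000 nM in this assay, at which 2 of the 3 values shown sit. The compounds shown leave open whether phenyl to 4-methoxyphenyl changes growth inhibition at all.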